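Pyridin-3-yl in Place of 2-Cyanophenyl on an Amide-Type Nitrogen

The source may report more compounds than this note shows. Statements on the series, on what has been measured and on what is new or still open speak of the compounds shown alone.

Measured compounds:
compound 1, `O=C(Nc1ccc(F)cc1)N1CCc2ccccc2[C@H]1c1ccc(C(F)(F)F)cc1`, 36 nM
compound 2, `N#Cc1ccccc1NC(=O)N1CCc2ccccc2[C@H]1c1ccc(C(F)(F)F)cc1`, 424 nM

Both compounds were tested in an assay on isolated protein for antagonist activity at transient receptor potential cation channel subfamily M member 8 (Homo sapiens), read by luminescence and calcium flux, with a stated time of 2.5 min; a higher number here means a weaker inhibitor, a lower number a stronger inhibitor. Compound 1 gives 36 nM, and compound 2 gives 424 nM. Of the two numbers, that of compound 2 is the higher: the step of a 12-fold higher number from compound 1 to compound 2 (1.07 log units; beyond the scatter) is large and lies beyond the scatter. Compound 2 therefore stands as the weaker of the two measured compounds in this assay.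

Compound 3, `O=C(Nc1cccnc1)N1CCc2ccccc2[C@H]1c1ccc(C(F)(F)F)cc1`, has not yet been measured. It differs from compound 2 in one place: pyridin-3-yl in place of 2-cyanophenyl on an amide-type nitrogen. Among the compounds with values here, the only measured step that bears on this position is a 12-fold higher number from compound 1 to compound 2 (1.07 log units; beyond the scatter), which shows that exchanging the aryl group on this nitrogen moves the number by a large amount. Compound 3 carries a group that is neither of the two measured ones, so the direction is not fixed by a direct precedent; still, because a 12-fold higher number from compound 1 to compound 2 (1.07 log units; beyond the scatter) was large, a step of some size is expected rather than none. Compound 3 is expected to give a lower number than compound 2, a step of about a 2.8-fold lower number from compound 2 to compound 3 (0.45 log units; beyond the scatter). The estimate for compound 3 in this assay is 150 nM, with a range from 40 nM to 600 nM.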

Compound 3, half-maximal inhibitory concentration: 28 nM
Compound 3: the middle estimate sits 5.4-fold (0.73 log units) above what was measured; the whole stated range lies above it.
By their numbers in this assay, from the lowest: compounds 3 and 1 (each within the scatter of the next); then compound 2.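

In this assay, the result shows that the large difference seen at the aryl group on this amide-type nitrogen is not a general cost of moving away from 4-fluorophenyl, since exchanging 2-cyanophenyl for pyridin-3-yl gives a 15-fold lower number from compound 2 to compound 3 (1.18 log units; beyond the scatter). Pyridin-3-yl and 4-fluorophenyl cannot be told apart here, at a 1.3-fold lower number from compound 1 to compound 3 (0.11 log units; within the scatter), so a six-membered aromatic ring with a hetero atom serves at this position as well as the fluorinated carbon ring, and among the three compounds only compound 2 stands apart. No supporting data bear on why compound 2 differs from the other two.

The compounds shown leave open whether the weaker result of compound 2 goes with the nitrile itself or with its placement on the ring, a question that a plain phenyl group or a 4-cyanophenyl group on this nitrogen would address. They also leave open how much the place of the ring nitrogen matters, which a pyridin-2-yl or pyridin-4-yl group would address.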